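A few compounds are considered here, and "the series" means these few. Any claim that something is new, unique, unknown or untested is made for them only; others in the source may bear on it.

Measured compounds:
compound 1, `Cc1nc(S(C)(=O)=O)ccc1Oc1ncnc(OC2CCN(C(=O)OC(C)(C)C(F)(F)F)CC2)c1F`, 47.2 nM
compound 2, `Cc1nc(S(C)(=O)=O)ccc1Oc1ncnc(OC2CCN(C(=O)O[C@@H](C)C(F)(F)F)CC2)c1F`, 109 nM
compound 3, `Cc1nc(S(C)(=O)=O)ccc1Oc1ncnc(OC2CCN(C(=O)SC3CCC3)CC2)c1F`, 77.4 nM

These three compounds share a common core and differ only in the group on the carbonyl carbon attached to the amide-type nitrogen in the ring. In a functional assay on isolated protein for inhibition of Glucose-dependent insulinotropic receptor (Rattus norvegicus), read by HTRF and cAMP accumulation (a higher number here means that more compound is needed for the effect, a lower number that less compound is needed), compound 3 stands second highest of the three numbers; its nearest neighbour is compound 2, and the gap from compound 2 to compound 3 is a 1.4-fold lower number from compound 2 to compound 3 (0.15 log units; within the scatter), while the gap from compound 1 to compound 3 is a 1.6-fold higher number from compound 1 to compound 3 (0.21 log units; within the scatter). Both of these lie within the scatter, so compound 3 cannot be ordered against either.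

Compound 4, `Cc1nc(S(C)(=O)=O)ccc1Oc1ncnc(OC2CCN(C(=O)C(C)(C)F)CC2)c1F`, is not yet measured. It differs from compound 3 in one place: 1-fluoro-1-methylethyl in place of cyclobutylsulfanyl on a carbonyl carbon. Going by the values given here, the steps that bear on this change are those that alter the same carbonyl substituent, namely a 1.6-fold higher number from compound 1 to compound 3 (0.21 log units; within the scatter) and a 1.4-fold lower number from compound 2 to compound 3 (0.15 log units; within the scatter), together with a 2.3-fold higher number from compound 1 to compound 2 (0.36 log units; beyond the scatter), which is modest. All three compounds sit within a narrow band, so no step beyond the scatter is expected in this assay for compound 4, in either direction. Compound 4 is therefore estimated at 90 nM, with a range from 35 nM to 250 nM, meaning an expected step of a 1.2-fold higher number from compound 3 to compound 4 (0.07 log units; within the scatter).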

Compound 4, half-maximal effective concentration: 296 nM
Estimate against measurement, compound 4: 3.3-fold (0.52 log units) below; the measured number lies above the stated range.
By their numbers in this assay, from the lowest: compounds 1, 3 and 2 (each within the scatter of the next, the first and the last beyond it); then compound 4.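

With 1-fluoro-1-methylethyl on the carbonyl carbon, this position gives for the first time a group that stands beyond the scatter from every other group shown in this assay: there is a 3.8-fold higher number from compound 3 to compound 4 (0.58 log units; beyond the scatter) and a 2.7-fold higher number from compound 2 to compound 4 (0.43 log units; beyond the scatter) and also a 6.3-fold higher number from compound 1 to compound 4 (0.80 log units; beyond the scatter) in the same direction. Going by these compounds alone, the earlier groups had left only one step beyond the scatter, whereas this change shows that the group on this carbonyl carbon can shift the number further, and it is the only one of the four that is joined there through carbon rather than through oxygen or sulfur. No measurement shown here explains this rise.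

Compound 4 differs from the others both in that linking atom and in the group as a whole, so the compounds shown cannot separate the two. A cyclobutyl group joined directly to the carbonyl carbon, or an amine on that same carbon, would be needed to tell whether the link alone goes with the higher number in this assay or whether the rest of the group also matters.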